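Sulfonamide series: cytotoxicity in HEK293 cells, one ring swap

A few compounds are considered here, and "the series" means these few. Any claim that something is new, unique, unknown or untested is made for them only; others in the source may bear on it.

Measured compounds:
compound 1 `O=S(=O)(Nc1ccc2oc(-c3ccccc3)nc2c1)c1cccc(F)c1`: 68000 nM
compound 2 `O=[N+]([O-])c1cc(S(=O)(=O)Nc2ccc(-c3nc4ccccc4o3)cc2)ccc1Cl`: 85000 nM
compound 3 `C=Cc1ccc(S(=O)(=O)Nc2ccc(-c3nc4ccccc4o3)cc2)cc1`: > 100000 nM

In an ADME assay on HEK293 cells (Homo sapiens) for cytotoxicity, read by resazurin assay, with a stated time of 48 h (a lower number here means that less compound is tolerated, a higher number that more compound is tolerated), compound 1 gives 68000 nM. Compound 2 gives 85000 nM in this assay, and the gap between compound 1 and compound 2 is within the usual scatter, so the two sit together. For compound 3 this assay reports only a limit, > 100000 nM, and no number; this is the limit of > 100000 nM in this assay, at which 1 of the 3 values shown sits. Of the two numbers available, compound 1 thus stands with compound 2, and neither of the two can be told apart from the other.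

Compound 4 `O=S(=O)(Nc1ccc2oc(-c3ccccc3)nc2c1)c1ccccc1O` is not yet measured. It differs from compound 1 in one place: 2-hydroxyphenyl in place of 3-fluorophenyl on a sulfonyl sulfur. Within the data shown here, no measured pair in this set shares that change, so there is no step to lean on; all three measured compounds tolerate the compound to a similar, high degree. Compound 4 is expected to follow the same pattern, with a step of a 1.1-fold higher number from compound 1 to compound 4 (0.04 log units; within the scatter) that is estimated to stay within the scatter in either direction. The estimate for compound 4 in this assay is 75000 nM, expected to fall between 35000 nM and 150000 nM.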

Compound 4, half-maximal cytotoxic concentration: 33000 nM
Compound 4: middle estimate off by 2.3-fold (0.36 log units), on the high side, outside the stated range (below it).
By their numbers in this assay, from the lowest: compound 4; then compounds 1 and 2 (each within the scatter of the next). At a limit, above all of these: compound 3.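

Among these compounds, earlier compounds gave no step, so the sulfonyl sulfur position had not been tested on its own; it now proves not to be neutral in this assay. With 2-hydroxyphenyl in place of 3-fluorophenyl on a sulfonyl sulfur and the shared core kept, the series shows a 2.1-fold lower number from compound 1 to compound 4 (0.31 log units; beyond the scatter), a modest step in the direction of less compound tolerated. Nothing on hand bears on the reason for this step.

This single step cannot separate the arrival of the hydroxyl from the departure of the fluorine, nor either of these from its place on the phenyl ring. Also open, going by these compounds, is how an unsubstituted phenyl, a 2-methoxyphenyl or a 2-aminophenyl on a sulfonyl sulfur would read in this assay.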